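Aryl versus methyl at the ring carbon: compound 4

This account rests on a few compounds, and the source may have more. Where it says the series, first, only, none or still open, it means among the compounds named here.

Working notes on a short series sharing one core, varied at a saturated ring carbon. Compound 1 `C=CC(=O)N1C(=O)CC(c2ccc(C(F)(F)F)cc2)Sc2ccccc21` gives 38600 nM in a functional assay on NB-4 cells (Homo sapiens) for cytotoxicity, read by CCK-8 assay, with a stated time of 24 h; a higher number here means a weaker inhibitor, a lower number a stronger inhibitor. Compound 2 `C=CC(=O)N1C(=O)CC(c2ccc(OC)cc2)Sc2ccccc21` gives 32900 nM in this assay; the step of a 1.2-fold lower number from compound 1 to compound 2 (0.07 log units; within the scatter) shows the two aryl-bearing compounds within scatter of each other. Compound 3 `C=CC(=O)N1C(=O)CC(C)Sc2ccccc21` gives 227000 nM and stands highest of the three numbers, beyond the scatter from both compound 1 and compound 2, the relevant step being a 6.9-fold higher number from compound 2 to compound 3 (0.84 log units; beyond the scatter).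

Compound 4 `C=CC(=O)N1C(=O)CC(c2ccccc2)Sc2ccccc21` is not yet measured. It differs from compound 3 by phenyl in place of methyl on a saturated ring carbon. Within the data shown here, the one measured step that bears on this change is a 6.9-fold higher number from compound 2 to compound 3 (0.84 log units; beyond the scatter), a modest rise when the aryl group was replaced by methyl; since compound 1 and compound 2 differ little, a phenyl without substituent is expected to behave like either aryl compound. The expected step is therefore a 6.3-fold lower number from compound 3 to compound 4 (0.80 log units; beyond the scatter), a lowering of the number. For compound 4 in this assay the estimate is 36000 nM, with a range of 16000 nM to 85000 nM.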

Compound 4, half-maximal inhibitory concentration: 35500 nM
Beside the measured number, compound 4's estimate is 1.0-fold (0.01 log units) above it; the range from low to high includes it.
By their numbers in this assay, from the lowest: compounds 2, 4 and 1 (each within the scatter of the next); then compound 3.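

Among these compounds, compound 4 gives the direct comparison of an unsubstituted phenyl with methyl on this saturated ring carbon in this assay (a 6.4-fold lower number from compound 3 to compound 4 (0.81 log units; beyond the scatter)), so the aromatic ring alone accounts for a step of the size earlier seen only with a substituted aryl group. A substituent on the aromatic ring is not needed to reach this level, since neither removing methoxy (a 1.1-fold higher number from compound 2 to compound 4 (0.03 log units; within the scatter)) nor removing trifluoromethyl (a 1.1-fold lower number from compound 1 to compound 4 (0.04 log units; within the scatter)) moves the number beyond the scatter. Nothing available explains why phenyl and methyl differ here.

Between methyl and phenyl the series holds no intermediate, so a longer chain at this ring carbon remains untested in these data. As far as these compounds go, whether an amine or a carboxylic acid on the aromatic ring would separate from the flat aryl trio also stays open.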